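Oxime ether series: para substituent swap on the benzyl ring

This account rests on a few compounds, and the source may have more. Where it says the series, first, only, none or still open, it means among the compounds named here.

Measured so far in a functional assay on A549 cells (Homo sapiens) for antiproliferative activity, tested at 1 uM; on this read-out higher numbers stand for more inhibition at the one concentration tested (going by the name of the read-out) and lower numbers for less inhibition:
- compound 1 `Cc1nn(-c2ccccc2)c(Oc2ccc(Cl)cc2)c1/C=N/OCc1ccc(C(=O)OC(C)(C)C)cc1`: -6.5%
- compound 2 `Cc1nn(C)c(Oc2ccc(Cl)cc2)c1/C=N/OCc1ccc([N+](=O)[O-])cc1`: 39.6%
- compound 3 `Cc1nn(C)c(Oc2ccccc2)c1/C=N/OCc1ccc([N+](=O)[O-])cc1`: 39.4%

Compound 2 stands highest of the three numbers, but its nearest neighbour, compound 3, is within the scatter of it: the step of a number 0.2 percentage points lower from compound 2 to compound 3 (within the scatter) shows hydrogen in place of chloro on an aromatic carbon leaves the read-out unchanged. Compound 1 lies far below, with a difference beyond the scatter; it differs from compound 2 in two places at once, so its value alone cannot be assigned to either change.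

The next compound, compound 4 `Cc1nn(C)c(Oc2ccc(Cl)cc2)c1/C=N/OCc1ccc(C(F)(F)F)cc1`, carries the change trifluoromethyl in place of nitro on an aromatic carbon relative to compound 2. Going by the values given here, no measured step varies the group on the benzyl ring while keeping the rest of compound 2 fixed, so the only bearing information is that compound 1, which holds a different para group together with another change, sits at -6.5%. A departure from the nitro group is therefore taken as a risk of losing part of the inhibition, though the size is uncertain.

The expected step in this assay is a number 14.6 percentage points lower from compound 2 to compound 4 (beyond the scatter). Compound 4 is estimated at 25%, within a range of 0% to 45%.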

Compound 4, a percentage reported as inhibition, at one concentration (the size of the read-out at that concentration, not a potency): 50.9%
Estimate against measurement, compound 4: 25.9 percentage points below; the measured number lies above the stated range.
By their numbers in this assay, from the lowest: compound 1; then compounds 3 and 2 (each within the scatter of the next); then compound 4.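

In this assay, going by these compounds alone, trifluoromethyl in place of nitro on an aromatic carbon para to a large group gives a number 11.3 percentage points higher from compound 2 to compound 4 (beyond the scatter), the first reading of this place with the rest of compound 2 held fixed. Nitro is therefore not needed here for inhibition at the one concentration tested, and hydrogen-bond acceptors at this place are not needed either, as trifluoromethyl has none; the value of compound 1, -6.5%, must still be read with its other change in play, so it says nothing about leaving nitro alone. Nothing available gives a reason for the rise from nitro to trifluoromethyl.

The compounds shown leave open whether the rise is particular to trifluoromethyl or would also appear with a nitrile, a methoxy group, an amine or a carboxylic acid at this place. Also open, going by these compounds, is whether the step of a number 0.2 percentage points lower from compound 2 to compound 3 (within the scatter) still holds with trifluoromethyl at this place, as that step has been read only with nitro.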